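The source may hold more compounds than are shown below. What is called first, only, known or untested is meant among the compounds shown, and "the series" means these compounds.

Within the data shown here, in an ADME assay on the whole organism (Mus musculus, strain Swiss Webster) for pharmacokinetics, read by LC-MS, at a dose of 50 mg/kg by the oral route (a lower number here means less compound in the circulation, a higher number more compound in the circulation at the dose given), compound 1 `O=C(Nc1ccc(F)c(-c2nc3ncc(-c4cc(F)ccc4F)cc3[nH]2)c1)N1CCCC1` gives 5620 ng.h/mL, the higher of the two numbers measured so far, and compound 2 `O=C(Nc1ccc(F)c(-c2nc3ncc(-c4cncc(F)c4)cc3[nH]2)c1)N1CCCC1` gives 1560 ng.h/mL. Compound 3 `O=C(Nc1ccc(F)c(-c2nc3ncc(-c4cccc(F)c4F)cc3[nH]2)c1)N1CCCC1` has not been measured. It carries 2,3-difluorophenyl in place of 2,5-difluorophenyl on an aromatic carbon of the shared core: 2,3-difluorophenyl in place of 2,5-difluorophenyl on an aromatic carbon. Among the measured compounds shown here, only one measured step touches this place: a 3.6-fold lower number from compound 1 to compound 2 (0.56 log units; beyond the scatter). That modest step replaced the 2,5-difluorophenyl with 5-fluoropyridin-3-yl, whereas here the entering ring remains of carbon only and the two compounds have the same atoms, joined differently. It is therefore a loose guide, and it gives no direction for a shift of fluorine alone. The estimated step is a 1.2-fold lower number from compound 1 to compound 3 (0.07 log units; within the scatter), which is expected to stay within the scatter. For compound 3 the expected value is 4800 ng.h/mL, with an estimated range from 2000 ng.h/mL to 11000 ng.h/mL.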

Compound 3, area under the concentration-time curve: 4750 ng.h/mL
Compound 3: the middle estimate sits 1.0-fold (0.00 log units) above what was measured, and the stated range covers the measured number.
By their numbers in this assay, from the lowest: compound 2; then compounds 3 and 1 (each within the scatter of the next).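

In this assay the shift of one fluorine, from 2,5-difluorophenyl to 2,3-difluorophenyl, gives a 1.2-fold lower number from compound 1 to compound 3 (0.07 log units; within the scatter) and so leaves the number unmoved beyond the scatter at this place on the shared core. The change from 5-fluoropyridin-3-yl to 2,3-difluorophenyl gives a 3.0-fold higher number from compound 2 to compound 3 (0.48 log units; beyond the scatter) and shows that the higher numbers are not confined to the 2,5-difluorophenyl arrangement, since both difluorophenyl compounds stand beyond the scatter from compound 2. Nothing available explains these numbers.

The 5-fluoropyridin-3-yl group differs from both difluorophenyl groups in its ring nitrogen and in its fluorine count, so the compounds shown cannot separate these two changes. Going by these compounds, it also remains open how a plain phenyl, a 3-fluorophenyl or a 3,5-difluorophenyl group would read at this place.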